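Swapping a Tetrazole for a Benzoylsulfamoyl Group

The source may hold more compounds than are shown below. What is called first, only, known or untested is meant among the compounds shown, and "the series" means these compounds.

Among the compounds with values here, compound 2 `CC(C)(N)CC(=O)N[C@@H]1CCc2ccccc2N(Cc2ccc(-c3ccccc3-c3nnnn3Cc3ccccc3)cc2)C1=O` gives the lowest of the two numbers measured so far in a functional assay (Pituitary gland cell) with Rattus norvegicus as the target (a lower number here means that less compound is needed, a higher number that more compound is needed for the effect), with a value of 0.7 uM. Its nearest neighbour, compound 1 `CC(C)(N)CC(=O)N[C@@H]1CCc2ccccc2N(Cc2ccc(-c3ccccc3C(=O)O)cc2)C1=O`, gives 3 uM in this assay, and the step of a 4.3-fold lower number from compound 1 to compound 2 (0.63 log units; beyond the scatter) lies beyond the usual scatter. Compound 3 `CC(C)(N)CC(=O)N[C@@H]1CCc2ccccc2N(Cc2ccc(-c3ccccc3S(=O)(=O)NC(=O)c3ccccc3)cc2)C1=O` has not yet been measured; it differs from compound 2 in one place: benzoylsulfamoyl in place of 1-benzyl-1H-tetrazol-5-yl on an aromatic carbon. Within the data shown here, the only step that bears on this change is the one from compound 1 to compound 2, in which a carboxy group on the same aromatic carbon was replaced by a larger group and the number fell modestly. The new group is of similar size to the one it replaces, so the expected step of a 1.4-fold higher number from compound 2 to compound 3 (0.15 log units; within the scatter) is small, with no clear direction beyond the scatter. Compound 3 is therefore estimated at 1 uM, within a range from 0.3 uM to 4 uM in this assay.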

Compound 3, concentration for half-maximal effect: 3 uM
Estimate against measurement, compound 3: 3.0-fold (0.48 log units) below; low and high end bracket the measured number.
By their numbers in this assay, from the lowest: compound 2; then compounds 1 and 3 (each within the scatter of the next).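

At this position, on an aromatic carbon ortho to a large group, two groups of 12 heavy atoms each do not give the same result in this assay: benzoylsulfamoyl in place of 1-benzyl-1H-tetrazol-5-yl gives a 4.3-fold higher number from compound 2 to compound 3 (0.63 log units; beyond the scatter) and so size alone does not set the number across compounds 2 and 3. The lower number seen with 1-benzyl-1H-tetrazol-5-yl is also not shared by every group larger than carboxy, since benzoylsulfamoyl in place of carboxy gives no change at the digits printed from compound 1 to compound 3 (within the scatter) in this comparison. No measurement is available here that would explain the difference between these groups.

From the compounds shown here alone, it remains open whether the benzyl group or the tetrazole ring matters more, which a plain tetrazole or a 1-methyltetrazole could help separate. Acetylsulfamoyl would likewise test the phenyl ring of benzoylsulfamoyl.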